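Decyl carbamate series: estimating the fluorophenyl analogue

This account rests on a few compounds, and the source may have more. Where it says the series, first, only, none or still open, it means among the compounds named here.

Measured so far in an assay on H4 cells for inhibition of Fatty-acid amide hydrolase 1 (Homo sapiens); on this read-out higher numbers stand for weaker inhibition and lower numbers for stronger inhibition:
Compound 1 `CCCCOc1ccc(NC(=O)Oc2ccccc2F)cc1` gives 340 nM.
Compound 2 `CCCCCCCCOc1ccc(NC(=O)Oc2ccccc2F)cc1` gives 19 nM.
Compound 3 `CCCCCCCCCCOc1ccc(NC(=O)O/N=C/c2ccc(F)cc2)cc1` gives 0.25 nM.

Compound 3 carries the lowest number of the three; its steps to compound 2 and to compound 1 both lie beyond the scatter. Compound 4 `CCCCCCCCCCOc1ccc(NC(=O)Oc2ccccc2F)cc1` differs from compound 3 by a group of 7 heavy atoms (6 carbon, 1 fluorine; one six-membered aromatic ring of carbon only) in place of a group of 9 heavy atoms (7 carbon, 1 nitrogen, 1 fluorine; one six-membered aromatic ring of carbon only), on an oxygen next to a carbonyl group. Among the compounds with values here, no measured step covers this exchange on the carbonyl oxygen. Within the data shown here, the one measured step, an 18-fold lower number from compound 1 to compound 2 (1.25 log units; beyond the scatter), concerns chain length only and suggests the longer chain of compound 4 should keep its number at or under that of compound 2. Compound 2 and compound 3 differ in two places at once, so their values alone cannot separate the two changes. A rise is therefore expected in this assay, roughly a 20-fold higher number from compound 3 to compound 4 (1.30 log units; beyond the scatter). Compound 4 is estimated at 5 nM, with a range of 1 nM to 25 nM.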

Compound 4, half-maximal inhibitory concentration: 9.2 nM
Compound 4: the middle estimate sits 1.8-fold (0.26 log units) below what was measured; the range from low to high includes it.
By their numbers in this assay, from the lowest: compound 3; then compound 4; then compound 2; then compound 1.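

In this assay, within the data shown here, 2-fluorophenyl on an oxygen next to a carbonyl group gives a 37-fold higher number from compound 3 to compound 4 (1.57 log units; beyond the scatter) with the decyl chain held fixed, the first direct reading of this exchange. With 2-fluorophenyl held, lengthening the chain gives a 2.1-fold lower number from compound 2 to compound 4 (0.31 log units; beyond the scatter) and a 37-fold lower number from compound 1 to compound 4 (1.57 log units; beyond the scatter) as a further result, so the decyl chain extends the downward trend, though its last step is modest. No evidence here bears on the reason for these steps.

As far as these compounds go, whether a dodecyl chain lowers the number further remains open. So does whether an unsubstituted phenyl on the same oxygen behaves like 2-fluorophenyl.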